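The source may hold more compounds than are shown below. What is called first, only, known or untested is meant among the compounds shown, and "the series" means these compounds.

Measured so far:
- Compound 1 `COc1ccc(C(=O)Nc2cc(OC)c(OC)c(OC)c2)cc1[N+](=O)[O-]`: 3700 nM
- Compound 2 `COc1ccc(C(=O)Nc2cc(OC)c(OC)c(OC)c2)cc1N`: > 100000 nM, a limit of the assay
- Compound 3 `COc1ccc(C(=O)Oc2cc(OC)c(OC)c(OC)c2)cc1[N+](=O)[O-]`: > 100000 nM, a limit of the assay

In a functional assay on HeLa cells (Homo sapiens) for antiproliferative activity, read by MTT assay, with a stated time of 72 h (on this read-out lower numbers stand for stronger inhibition and higher numbers for weaker inhibition), compound 1 gives 3700 nM. For compound 2 the read-out is only a limit of the assay, not a number. The change between them is amino in place of nitro on an aromatic carbon, and it produced an at least 27-fold higher number from compound 1 to compound 2 (1.43 log units; beyond the scatter). This is consistent with the limit of > 100000 nM in this assay, at which 2 of the 3 values shown sit.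

Compound 3 also reaches only a limit of the assay. How the core of compound 3 differs from the core of compound 1 is not broken down here.

Compound 4 `COc1ccc(C(=O)Oc2cc(OC)c(OC)c(OC)c2)cc1N` is not yet measured. Within the data shown here, it differs from compound 3 by amino in place of nitro on an aromatic carbon, which is the same change as the one from compound 1 to compound 2. Since compound 3 already sits at the limit, and the earlier step was a large loss, compound 4 is expected to stay at or beyond that limit, a step that the limit leaves unreadable from compound 3 to compound 4. The estimate for compound 4 in this assay is 200000 nM, most likely reported only as a limit.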

Compound 4, half-maximal inhibitory concentration: > 100000 nM
Compound 4: only a limit was reported; the forecaster's own chance of this, stated with the estimate: 90%; the middle value lies beyond the limit too.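

In this assay compound 3 and compound 4 both reach only a limit of the assay, not a number, so the step between them cannot be read: the limit of > 100000 nM in this assay, at which 3 of the 4 values shown sit.

The compounds shown leave open whether amino in place of nitro changes the read-out at all on the core of compound 3, as it does on the core of compound 1.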